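Aryl substituent changes on the benzyl ether and binding

The source may hold more compounds than are shown below. What is called first, only, known or untested is meant among the compounds shown, and "the series" means these compounds.

Compound 1 `N[C@]1(C(=O)O)[C@H]2[C@@H](C[C@H]1OCc1ccccc1)[C@]2(F)C(=O)O` gives 7.14 nM in an assay on CHO cells for binding affinity to metabotropic glutamate receptor 2 (Rattus norvegicus); a higher number here means a weaker inhibitor, a lower number a stronger inhibitor.
Compound 2 `N[C@]1(C(=O)O)[C@H]2[C@@H](C[C@H]1OCc1cccc(Br)c1)[C@]2(F)C(=O)O` gives 4.71 nM in this assay.
Compound 3 `Nc1cccc(CO[C@@H]2C[C@@H]3[C@H]([C@]2(N)C(=O)O)[C@@]3(F)C(=O)O)c1` gives 15.4 nM in this assay.

Compound 3 has the highest number of the three in this assay. Compound 1 stands nearest to it and compound 2 furthest, and both steps lie beyond the scatter: a 2.2-fold higher number from compound 1 to compound 3 (0.33 log units; beyond the scatter) and a 3.3-fold higher number from compound 2 to compound 3 (0.51 log units; beyond the scatter). Between compound 1 and compound 2 the step is small, a 1.5-fold lower number from compound 1 to compound 2 (0.18 log units; within the scatter).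

Compound 4 `N[C@]1(C(=O)O)[C@H]2[C@@H](C[C@H]1OCc1c(F)cccc1F)[C@]2(F)C(=O)O` has not yet been measured in this assay. It differs from compound 3 by 2,6-difluorophenyl in place of 3-aminophenyl on a saturated chain carbon bound to an oxygen on a saturated carbon. Going by the values given here, no measured pair exchanges one substituted phenyl for another of this kind, so the nearest guides are the single-substituent steps. The bromo-for-hydrogen step, a 1.5-fold lower number from compound 1 to compound 2 (0.18 log units; within the scatter), did not move the number beyond the scatter, whereas the amino-for-hydrogen step, a 2.2-fold higher number from compound 1 to compound 3 (0.33 log units; beyond the scatter), raised it modestly. Exchanging the aminophenyl of compound 3 for a difluorophenyl is therefore expected to bring compound 4 back toward the numbers of compound 1 and compound 2, an estimated step of a 2.2-fold lower number from compound 3 to compound 4 (0.34 log units; beyond the scatter). For compound 4 the estimated value in this assay is 7 nM, with a range from 3 nM to 18 nM.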

Compound 4, inhibition constant: 7.02 nM
Beside the measured number, compound 4's estimate is 1.0-fold (0.00 log units) below it; measured number inside the range.
By their numbers in this assay, from the lowest: compounds 2, 4 and 1 (each within the scatter of the next); then compound 3.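

In this assay, the place on a saturated chain carbon bound to an oxygen on a saturated carbon also accepts a phenyl carrying two substituents, and 2,6-difluorophenyl reads level with both plain phenyl (a 1.0-fold lower number from compound 1 to compound 4 (0.01 log units; within the scatter)) and 3-bromophenyl (a 1.5-fold higher number from compound 2 to compound 4 (0.17 log units; within the scatter)). The exchange of 3-aminophenyl for 2,6-difluorophenyl (a 2.2-fold lower number from compound 3 to compound 4 (0.34 log units; beyond the scatter)) now shows that the higher number of compound 3 does not extend to every substituted phenyl: among these four compounds, only compound 3 stands apart, while compound 1, compound 2 and compound 4 lie within the scatter of one another. Nothing available explains why compound 3 alone stands apart from the other three.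

Going by these compounds, what stays open is whether a hydroxyl, a methoxy or a carboxylic acid in place of the amino group would raise the number as the amino group does, and whether a single fluorine would read like the pair. Also open, on these data alone, is how a pyridine in place of the phenyl, or a longer chain in place of the saturated chain carbon, would read in this assay.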